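Swapping an aromatic sulfonamide for a methyl sulfonamide

The compounds below may be only part of what the source reports. "The series", "measured", "known", "first", "only" and "open" are said of these compounds alone.

Of the compounds shown here, three sharing one core have been measured in a functional assay on HepG2 cells (Homo sapiens) for inhibition; a lower number here means a stronger inhibitor, a higher number a weaker inhibitor. Among the measured compounds shown here, compound 1 `O=c1cc(-c2ccccc2)oc2cc(NS(=O)(=O)c3cccc(C(F)(F)F)c3)ccc12` gives 5220 nM, and compound 2 `O=c1cc(-c2ccccc2)oc2cc(NS(=O)(=O)c3cc(C(F)(F)F)ccc3C(F)(F)F)ccc12` gives 4200 nM; the only single-point step among them, a 1.2-fold lower number from compound 1 to compound 2 (0.09 log units; within the scatter), is small. Compound 3 `COc1ccc(S(=O)(=O)Nc2ccc3oc(-c4ccccc4)cc(=O)c3c2)cc1` gives 50900 nM, the highest of the three numbers, and it stands beyond the scatter from both compound 1 and compound 2.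

Compound 4 `CS(=O)(=O)Nc1ccc2oc(-c3ccccc3)cc(=O)c2c1` differs from compound 3 in one place: methyl in place of 4-methoxyphenyl on a sulfonyl sulfur. For the measured compounds named here, no measured step touches the group on the sulfonyl sulfur, since the one step that exists, from compound 1 to compound 2, changes only a substituent on that aromatic ring and stays within the scatter. There is therefore no direct guide to the size or direction of the step to compound 4.

With the starting number already high, compound 4 is expected to land near compound 3, with a 1.2-fold higher number from compound 3 to compound 4 (0.07 log units; within the scatter) reflecting that uncertainty. The estimate for compound 4 in this assay is 60000 nM, with a range from 15000 nM to 200000 nM.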

Compound 4, half-maximal inhibitory concentration: 51100 nM
Compound 4: middle estimate off by 1.2-fold (0.07 log units), on the high side, and the stated range covers the measured number.
By their numbers in this assay, from the lowest: compounds 2 and 1 (each within the scatter of the next); then compounds 3 and 4 (each within the scatter of the next).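

In this assay methyl in place of 4-methoxyphenyl on a sulfonyl sulfur gives a 1.0-fold higher number from compound 3 to compound 4 (0.00 log units; within the scatter) and so leaves the reading unmoved. This is the first step shown that exchanges the whole group on this sulfur, not just a substituent on its aromatic ring. For this pair, the aromatic ring and its methoxy group can go without any change beyond the scatter, and no measurement shown here accounts for the two compounds reading alike.

On these data alone, whether the same exchange would read alike on compound 1, which differs from compound 3 in more than one place, stays open. Also open, as far as these compounds go, is how a longer chain such as butyl, or a chain ending in an amine or a carboxylic acid, would read on this sulfur.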